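Trading the aryl ketone for a cyclohexyl ketone

The compounds below may be only part of what the source reports. "The series", "measured", "known", "first", "only" and "open" are said of these compounds alone.

Compound 2 `COc1ccccc1C(=O)c1ccn(-c2ccc3c(c2)B(O)OC3)c1` has been tested in an ADME assay on L929 cells (Mus musculus) for cytotoxicity, read by resazurin assay, with a stated time of 72 h; a higher number here means a weaker inhibitor, a lower number a stronger inhibitor. In this assay compound 2 gives only a limit, > 10 ug/mL. Compound 1 `CCc1ccc(C(=O)c2ccn(-c3ccc4c(c3)B(O)OC4)c2)cc1` likewise gives only a limit in this assay, > 10 ug/mL. Both values sit at the limit of > 10 ug/mL in this assay, at which 2 of the 2 values shown sit, so the step that the two limits leave unreadable from compound 1 to compound 2 cannot be sized. Compound 3 `O=C(c1ccn(-c2ccc3c(c2)B(O)OC3)c1)C1CCCCC1` carries the change (cyclohexyl in place of 2-methoxyphenyl on a carbonyl carbon). No readable measured step bears on it, so nothing here points to a change beyond the usual scatter. Compound 3 is therefore expected to show a step that the limit leaves unreadable from compound 2 to compound 3, most likely ending again at a limit. The estimated value for compound 3 is 20 ug/mL, with a range from 7 ug/mL to 60 ug/mL.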

Compound 3, half-maximal inhibitory concentration: > 10 ug/mL
Compound 3 was reported as a limit; the forecaster's own chance of this, stated with the estimate: 80%; the middle value lies beyond the limit too.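

No step can be read among compound 1, compound 2 and compound 3, because each is reported only as a limit: the limit of > 10 ug/mL in this assay, at which 3 of the 3 values shown sit. The compounds shown leave open whether exchanging the group on the carbonyl carbon changes the result in this assay at all.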